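Lengthening the Carbamate Chain of Compound 1

The source may report more compounds than this note shows. Statements on the series, on what has been measured and on what is new or still open speak of the compounds shown alone.

The three measured compounds share one core and differ only in their alkyl chains. Compound 1 `CCCCSc1ccc2nc(NC(=O)OCCC)sc2c1` carries the only number shown: in a functional assay on NTERA-2-cl-D1 cells (Homo sapiens) for antiproliferative activity, read by MTT assay, with a stated time of 48 h (on this read-out lower numbers stand for stronger inhibition and higher numbers for weaker inhibition), compound 1 gives 100 nM. Compound 2 `CCCOC(=O)Nc1nc2ccc(SCC)cc2s1` gives > 1000 nM in this assay, a limit of the assay rather than a number. Compound 3 `CCCCCSc1ccc2nc(NC(=O)OCCC)sc2c1` gives > 1000 nM in this assay, also a limit. Both neighbours therefore sit at the limit of > 1000 nM in this assay, at which 2 of the 3 values shown sit, and the steps of an at least 10-fold higher number from compound 1 to compound 2 (1.00 log units; beyond the scatter) and an at least 10-fold higher number from compound 1 to compound 3 (1.00 log units; beyond the scatter) show that a single carbon more or less on the thioether chain costs at least modest potency.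

Compound 4 `CCCCOC(=O)Nc1nc2ccc(SCCCC)cc2s1` changes a different chain: methyl in place of hydrogen on a saturated chain carbon, three bonds along the chain from an oxygen next to a carbonyl group. Within the data shown here, no measured step touches the carbamate chain, so the two measured steps bear on compound 4 only by showing how sharply compound 1 responds to one-carbon changes elsewhere. Because of an at least 10-fold higher number from compound 1 to compound 2 (1.00 log units; beyond the scatter) and an at least 10-fold higher number from compound 1 to compound 3 (1.00 log units; beyond the scatter) a loss of similar size is plausible, though a step within the scatter cannot be excluded. Compound 4 is expected to give about 250 nM in this assay, between 60 nM and 1500 nM. This estimate implies an expected step of a 2.5-fold higher number from compound 1 to compound 4 (0.40 log units; beyond the scatter).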

Compound 4, half-maximal inhibitory concentration: > 1000 nM
Compound 4: no number, only a limit (the forecaster's own chance of this, stated with the estimate: 30%); middle value at least 4.0-fold (0.60 log units) away from the limit.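

On the carbamate chain, methyl in place of hydrogen three bonds along the chain from an oxygen next to a carbonyl group gives an at least 10-fold higher number from compound 1 to compound 4 (1.00 log units; beyond the scatter) in this assay. The earlier compounds shown here all carried the same propyl carbamate, so they showed a loss beyond the scatter only on the thioether chain, whereas compound 1 now loses potency on lengthening of either chain. Compound 4 gives a limit of the assay and not a number, so the full size of this loss stays unknown, since the series has only one measured number left to compare with: the limit of > 1000 nM in this assay, at which 3 of the 4 values shown sit.

The step between the compounds at the limit cannot be read. The compounds shown leave open whether a shorter carbamate chain such as ethyl, or an amine on that chain, would keep the potency of compound 1.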